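A few compounds are considered here, and "the series" means these few. Any claim that something is new, unique, unknown or untested is made for them only; others in the source may bear on it.

Measured compounds:
compound 1, `CN(C)Cc1ccc2nc(NC(=O)N/N=C/c3cn(Cc4ccccc4)c4ccccc34)sc2c1`: 400 nM
compound 2, `CCN(CC)Cc1ccc2nc(NC(=O)N/N=C/c3cn(Cc4ccccc4)c4ccccc34)sc2c1`: 450 nM

In a functional assay on NCI-H460 cells (Homo sapiens) for cytotoxicity, read by MTT assay, with a stated time of 72 h (a higher number here means a weaker inhibitor, a lower number a stronger inhibitor), compound 1 shows the lower of the two numbers, though the step of a 1.1-fold higher number from compound 1 to compound 2 (0.05 log units; within the scatter) is within the scatter, so neither compound can be set ahead of the other. Compound 3, `CN(C)Cc1ccc2nc(NC(=O)N/N=C/c3cn(Cc4cccc(Cl)c4)c4ccccc34)sc2c1`, differs from compound 1 by chloro in place of hydrogen on an aromatic carbon. Within the data shown here, the one measured step concerns a different part of the molecule, the amine on the saturated chain carbon, and was within the scatter, so nothing measured bears directly on the change to compound 3. No step beyond the scatter is therefore expected. Compound 3 is estimated at 400 nM, ranging from 150 nM to 1000 nM. The expected step is no change at the digits printed from compound 1 to compound 3 (within the scatter).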

Compound 3, half-maximal inhibitory concentration: 420 nM
Compound 3: the middle estimate sits 1.1-fold (0.02 log units) below what was measured, and the stated range covers the measured number.
By their numbers in this assay, from the lowest: compounds 1, 3 and 2 (each within the scatter of the next).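

In this assay, chloro in place of hydrogen on an aromatic carbon of the benzyl group gives a 1.1-fold higher number from compound 1 to compound 3 (0.02 log units; within the scatter) and so leaves the number within the scatter. Among these compounds, this is the first measured change at the benzyl end, since the earlier step concerned only the amine on the chain. No measurement shown here explains this result. As far as these compounds go, whether a methoxy group or a nitrile at this place, or chloro on another ring carbon, would also stay within the scatter remains open. So does the effect of a morpholine in place of the dimethylamino group.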